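Nitro to Methoxy Exchange and Acid Dissociation

A few compounds are considered here, and "the series" means these few. Any claim that something is new, unique, unknown or untested is made for them only; others in the source may bear on it.

Measured compounds:
compound 1, `O=[N+]([O-])C1=Cc2ccccc2OC1Nc1cccc([N+](=O)[O-])c1`, 2.47
compound 2, `O=[N+]([O-])C1=Cc2ccccc2OC1Nc1ccc([N+](=O)[O-])cc1`, 1
compound 3, `COc1cccc(NC2Oc3ccccc3C=C2[N+](=O)[O-])c1`, 4.2

Of the compounds shown here, three have been measured in a physicochemical assay for acid dissociation. Compound 1 gives 2.47, compound 2 gives 1, and compound 3 gives 4.2. Compound 2 stands lowest of the three, beyond the scatter from both others. Compound 1 and compound 2 share the same atoms joined differently; the difference between these two cores is not broken down here.

From compound 1 to compound 3 the change is methoxy in place of nitro on an aromatic carbon, and in this assay this gave a number 1.73 log units higher from compound 1 to compound 3 (beyond the scatter).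

Compound 4, `COc1ccc(NC2Oc3ccccc3C=C2[N+](=O)[O-])cc1`, has not yet been measured. It differs from compound 2 by methoxy in place of nitro on an aromatic carbon. This is the same kind of change as that from compound 1 to compound 3, but the place differs: meta to a large group in the earlier pair, para to a large group here.

Compound 4 is expected to give 3.5, between 2.7 and 4.4. The expected step of a number 2.50 log units higher from compound 2 to compound 4 (beyond the scatter) is taken as somewhat larger than the earlier step, resting on a number 1.73 log units higher from compound 1 to compound 3 (beyond the scatter) and on the differing place.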

Compound 4, acid dissociation constant: 5.31
Estimate against measurement, compound 4: 1.81 log units below; the whole stated range lies below it.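

In this assay, methoxy in place of nitro on an aromatic carbon again gives a higher number, with a number 4.31 log units higher from compound 2 to compound 4 (beyond the scatter) set against a number 1.73 log units higher from compound 1 to compound 3 (beyond the scatter) in the earlier pair. The direction of the change therefore carries from the core of compound 1 to the core of compound 2 and both steps are large, but the size does not carry over: the step with the group para to a large group is the bigger of the two, and two pairs establish no rule for any other core or place. The data give no measured reason for this difference in size.

The compounds shown leave open whether an amine or a carboxylic acid in place of the nitro would move the number in the same direction, and how far. From the compounds shown here alone, it also remains open whether a longer chain, such as ethoxy in place of methoxy, would behave as methoxy does at either place.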